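This account rests on a few compounds, and the source may have more. Where it says the series, first, only, none or still open, it means among the compounds named here.

Compound 1 `Cn1ncc(Cl)c1-c1cc(C(=O)N[C@@H]2CN[C@H](CC(O)CO)C[C@H]2c2ccc(F)c(F)c2)oc1Cl` was tested in an assay for inhibition of RAC-alpha serine/threonine-protein kinase (Homo sapiens), read by HTRF, with a stated time of 1 h (a higher number here means a weaker inhibitor, a lower number a stronger inhibitor), where compound 1 gives 3.31 nM. Compound 2 `CC(=O)NCC[C@@H]1C[C@@H](c2ccc(F)c(F)c2)[C@H](NC(=O)c2cc(-c3c(Cl)cnn3C)c(Cl)o2)CN1` carries acetamidomethyl in place of the 1,2-dihydroxyethyl of compound 1, and in this assay compound 2 gives 2.49 nM. The change is a 1.3-fold lower number from compound 1 to compound 2 (0.12 log units; within the scatter). Among the two numbers in hand, compound 2 has the one that reads lower, but its only neighbour, compound 1, lies within the scatter of it, so the two cannot be ordered.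

Compound 3 `CC(=O)OCC[C@@H]1C[C@@H](c2ccc(F)c(F)c2)[C@H](NC(=O)c2cc(-c3c(Cl)cnn3C)c(Cl)o2)CN1` differs from compound 2 by acetoxy in place of acetamido on a saturated chain carbon, two bonds along the chain from a saturated ring carbon. Among the compounds with values here, the single measured step that touches this chain, a 1.3-fold lower number from compound 1 to compound 2 (0.12 log units; within the scatter), stayed within the scatter, so a similar outcome is expected here. Compound 3 is therefore expected to give about 3 nM in this assay, in a range from 1.2 nM to 7.5 nM. The expected step of a 1.2-fold higher number from compound 2 to compound 3 (0.08 log units; within the scatter) is one that would not stand out from the scatter.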

Compound 3, half-maximal inhibitory concentration: 3.4 nM
Beside the measured number, compound 3's estimate is 1.1-fold (0.05 log units) below it; measured number inside the range.
By their numbers in this assay, from the lowest: compounds 2, 1 and 3 (each within the scatter of the next).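

In this assay, acetoxy in place of acetamido on this chain gives a 1.4-fold higher number from compound 2 to compound 3 (0.14 log units; within the scatter), so a group with 0 hydrogen-bond donors cannot be told apart here from one with 1 hydrogen-bond donor. The comparison with the 1,2-dihydroxyethyl chain, acetoxymethyl in its place, gives a 1.0-fold higher number from compound 1 to compound 3 (0.01 log units; within the scatter), which means that compounds 1, 2 and 3 cannot be ordered and that all three side chains are tolerated to the same measurable degree in this assay. Nothing in hand offers an explanation for why these groups read alike.

From the compounds shown here alone, what remains open is whether any group at this place would move the number beyond the scatter. An amine, a carboxylic acid or a longer chain at this position could show whether this tolerance extends further.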